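Swapping nitro for acetamido on a sigma ligand

This account rests on a few compounds, and the source may have more. Where it says the series, first, only, none or still open, it means among the compounds named here.

The measured compounds:
compound 1 `COc1cccc2c1CCC(=O)N2CCCN1CCN(c2cccc([N+](=O)[O-])c2)CC1` gives 870 nM in an assay on cell membranes for binding affinity to Sigma non-opioid intracellular receptor 1 (Rattus norvegicus); a higher number here means a weaker inhibitor, a lower number a stronger inhibitor
compound 2 `O=C1CCc2c(Cl)cccc2N1CCCN1CCN(c2cccc([N+](=O)[O-])c2)CC1` gives 390 nM in this assay

Among the measured compounds shown here, compound 2 holds the lower of the two numbers in this assay; the one measured step, a 2.2-fold lower number from compound 1 to compound 2 (0.35 log units; beyond the scatter), separates it from compound 1. Compound 3 `CC(=O)Nc1cccc(N2CCN(CCCN3C(=O)CCc4c(Cl)cccc43)CC2)c1` has not yet been measured. It differs from compound 2 at a single place: acetamido in place of nitro on an aromatic carbon. For the measured compounds named here, the only measured step concerns chloro in place of methoxy and leaves the nitro group untouched, so no measured step bears on this change, and neither direction can be anchored in the data. For compound 3 the expected step is a 2.6-fold higher number from compound 2 to compound 3 (0.41 log units; beyond the scatter), a modest one, with a wide range allowed for the lack of any guiding step. Compound 3 is therefore estimated at 1000 nM in this assay, expected to lie between 300 nM and 4000 nM.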

Compound 3, half-maximal inhibitory concentration: 670 nM
Estimate against measurement, compound 3: 1.5-fold (0.17 log units) above; low and high end bracket the measured number.
By their numbers in this assay, from the lowest: compounds 2, 3 and 1 (each within the scatter of the next, the first and the last beyond it).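

Among the compounds shown here, the earlier compounds varied only the chloro and methoxy groups and left the nitro group in place, so this is the first reading at the position meta to a large group. In this assay, the change from 3-nitrophenyl to 3-acetamidophenyl gives a 1.7-fold higher number from compound 2 to compound 3 (0.24 log units; within the scatter) and so does not separate the two groups, although acetamido carries a hydrogen-bond donor that nitro lacks. Nothing available explains why the two groups read alike.

The compounds shown leave open whether an amine or a carboxylic acid at this same place would also read like nitro and acetamido. They also leave open whether acetamido would behave the same way on the methoxy-bearing core of compound 1.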